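Series notes: methoxy to 2-oxopyrrolidin-1-yl

The source may report more compounds than this note shows. Statements on the series, on what has been measured and on what is new or still open speak of the compounds shown alone.

Measured in a functional assay on A549 cells (Homo sapiens) for inhibition, read by sulforhodamine B assay, with a stated time of 74 h; on this read-out higher numbers stand for weaker inhibition and lower numbers for stronger inhibition:
- compound 1 `O=C1C=CC2(C=C1)OCC(=O)N2S(=O)(=O)c1ccc([N+](=O)[O-])cc1`: > 10000 nM (a limit)
- compound 2 `COc1ccc(S(=O)(=O)N2C(=O)COC23C=CC(=O)C=C3)cc1`: > 10000 nM (a limit)

In this assay compound 2 gives > 10000 nM, which is a limit and not a number. Compound 3 `O=C1C=CC2(C=C1)OCC(=O)N2S(=O)(=O)c1ccc(N2CCCC2=O)cc1` carries a 2-oxopyrrolidin-1-yl in place of methoxy on an aromatic carbon. Among the compounds with values here, the one measured step, a step that the two limits leave unreadable from compound 1 to compound 2, offers no size to carry over, and the only guide is the limit of > 10000 nM in this assay, at which 2 of the 2 values shown sit. No step beyond the scatter is therefore expected in this assay, and no direction can be favoured. The expected step is a step that the limit leaves unreadable from compound 2 to compound 3. For compound 3 the estimate is 12000 nM, with an expected range of 3000 nM to 30000 nM.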

Compound 3, half-maximal inhibitory concentration: 5 nM
Compound 3: middle estimate off by 2400-fold (3.38 log units), on the high side; measured number below the stated range.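

In this assay, the aromatic carbon para to a large group proves highly sensitive to its substituent: 2-oxopyrrolidin-1-yl gives an at least 2000-fold lower number from compound 2 to compound 3 (3.30 log units; beyond the scatter) and an at least 2000-fold lower number from compound 1 to compound 3 (3.30 log units; beyond the scatter). Methoxy and nitro had shown no readable difference, as the step between compound 1 and compound 2 cannot be read between two limits. Compound 3 gives this position its first measurable value on the shared core.

On these data alone, it remains open whether the lactam carbonyl or the ring is what matters. A plain pyrrolidin-1-yl amine or an open-chain acetamide at this place would separate the two.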